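The source may report more compounds than this note shows. Statements on the series, on what has been measured and on what is new or still open speak of the compounds shown alone.

Measured compounds in an assay for inhibition of 15-hydroxyprostaglandin dehydrogenase [NAD(+)] (Homo sapiens), read by fluorescence and spectrophotometry; on this read-out lower numbers stand for stronger inhibition and higher numbers for weaker inhibition:
compound 1 `O=C1NC(=O)/C(=C/c2ccc(OCCC3CCCCO3)cc2)S1` gives 750 nM
compound 2 `Cc1ncsc1CCOc1ccc(/C=C2\SC(O)=NC2=O)cc1` gives 636 nM
compound 3 `COc1ccc(COc2ccc(/C=C3\SC(=O)NC3=O)cc2)cc1` gives 529 nM

Among these three numbers compound 2 stands second highest, with compound 1 nearest to it and compound 3 furthest, and both of those gaps lie within the scatter of this assay, so the three compounds cannot be told apart on potency.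

Compound 4 `Cc1ccc(COc2ccc(/C=C3\SC(O)=NC3=O)cc2)cc1` has not yet been measured. It arises from compound 2 by one change: 4-methylphenyl in place of (4-methyl-1,3-thiazol-5-yl)methyl on a saturated chain carbon bound to an oxygen on an aromatic ring. Among the measured compounds shown here, one measured step bears on this kind of exchange, in which a saturated methylene-linked ring is swapped for an aromatic ring bound directly to the same chain carbon: the step of a 1.4-fold lower number from compound 1 to compound 3 (0.15 log units; within the scatter). That step stayed within the scatter, which suggests the corresponding exchange here should also give no step beyond the scatter in this assay.

Compound 4 is therefore expected to give about 500 nM in this assay, with a range of 250 nM to 1000 nM. This estimate means a step of a 1.3-fold lower number from compound 2 to compound 4 (0.10 log units; within the scatter), expected to be within the scatter.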

Compound 4, half-maximal inhibitory concentration: 232 nM
Estimate against measurement, compound 4: 2.2-fold (0.33 log units) above; measured number outside the range, below it.
By their numbers in this assay, from the lowest: compound 4; then compounds 3, 2 and 1 (each within the scatter of the next).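

In this assay, the change a 2.7-fold lower number from compound 2 to compound 4 (0.44 log units; beyond the scatter) is the only step shown that goes beyond the scatter, so the group on this saturated chain carbon bound to an oxygen on an aromatic ring can affect inhibition. Size counted as heavy atoms does not separate the two groups, as (4-methyl-1,3-thiazol-5-yl)methyl and 4-methylphenyl both have 7; they differ in ring type and in hetero atoms, with 2 hydrogen-bond acceptors leaving and 0 entering. Nothing measured here explains the gain.

Going by these compounds, it remains open whether the methyl group on the phenyl ring matters, which an unsubstituted phenyl would test. On these data alone, the effects of a 4-chlorophenyl group, a pyridine ring or a longer chain at this place also remain unknown.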